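Acetamido to benzamido in two related pairs of compounds

The compounds below may be only part of what the source reports. "The series", "measured", "known", "first", "only" and "open" are said of these compounds alone.

Compound 1 `CC(=O)Nc1cc(NC(=O)Nc2ccc(C)c(C)c2)ccc1C` carries an acetamido group, and compound 2 `Cc1ccc(NC(=O)Nc2ccc(C)c(NC(=O)c3ccccc3)c2)cc1C` differs from it by phenyl in place of methyl on a carbonyl carbon. In a functional assay on A375P cells (Homo sapiens) for antiproliferative activity (on this read-out lower numbers stand for stronger inhibition and higher numbers for weaker inhibition), compound 1 gives only a limit, > 30000 nM. In this assay compound 2 likewise gives only a limit, > 30000 nM. The step that the two limits leave unreadable from compound 1 to compound 2 is therefore not readable. Compound 3 `CC(=O)Nc1cc(NC(=O)c2ccc(Cl)c(C(F)(F)F)c2)ccc1C` keeps the acetamido group of compound 1 but differs from it in more than one place; the difference between the two cores is not broken down here. In this assay compound 3 also gives only a limit, > 30000 nM. Every measured value in this set sits at the limit of > 30000 nM in this assay, at which 3 of the 3 values shown sit.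

Compound 4 `Cc1ccc(NC(=O)c2ccc(Cl)c(C(F)(F)F)c2)cc1NC(=O)c1ccccc1` is the unmeasured partner of compound 3: it differs by phenyl in place of methyl on a carbonyl carbon. The place of this change reads word for word as it does for the pair of compound 1 and compound 2, so it is the same change, made a second time. Because the measured step that the two limits leave unreadable from compound 1 to compound 2 cannot be read from two limits, the size of the corresponding step for compound 4 has no measured anchor.

In this assay compound 4 is expected to give 30000 nM, with an estimated range from 10000 nM to 100000 nM. The expected step of a number no higher from compound 3 to compound 4 (the limit leaves the size open) is thus estimated as no real change. This expectation rests on compound 3 showing > 30000 nM in this assay, and on the same change leaving compound 2 at a limit as well.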

Compound 4, half-maximal inhibitory concentration: > 30000 nM
Compound 4 ended at the assay's limit; the forecaster's own chance of this, stated with the estimate: 70%; the middle value sits exactly at the limit.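

Among the compounds shown here, compound 3 and compound 4 both give only a limit in this assay, so no step between them can be read. All the compounds shown now stand at the same place: the limit of > 30000 nM in this assay, at which 4 of the 4 values shown sit. The compounds shown leave open whether benzamido in place of acetamido changes the read-out in either pair, and what change to the shared core would bring a value within the measurable range.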